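Thiazole amide series: nitrile in place of trifluoromethyl

This account rests on a few compounds, and the source may have more. Where it says the series, first, only, none or still open, it means among the compounds named here.

Measured compounds and values:
compound 1 `CNC(=O)[C@H](c1ccc(Cl)cc1)C(C)C` — in a functional assay on CHO cells for agonist activity at Free fatty acid receptor 2 (Homo sapiens), read by cAMP accumulation (a lower number here means a stronger inhibitor, a higher number a weaker inhibitor), compound 1 gives 11000 nM
compound 2 `CC(C)[C@H](C(=O)NC1=NC(=O)CS1)c1ccc(Cl)cc1` — in this assay compound 2 gives 20000 nM
compound 3 `CC(C)[C@H](C(=O)Nc1ncc(C(F)(F)F)s1)c1ccc(Cl)cc1` — in this assay compound 3 gives 1500 nM

Compound 3 holds the lowest of the three numbers, and both other compounds lie beyond the scatter above it. Among the compounds with values here, the only single-point step among measured compounds is a 1.8-fold higher number from compound 1 to compound 2 (0.26 log units; within the scatter), a replacement on the amide-type nitrogen; it does not touch the ring substituent and so gives no direct guide to the present change.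

Compound 4 `CC(C)[C@H](C(=O)Nc1ncc(C#N)s1)c1ccc(Cl)cc1` differs from compound 3 by cyano in place of trifluoromethyl on an aromatic carbon. Within the data shown here, no measured pair varies this position, so the expectation rests on the absence of any observed step at this place: the estimated step of a 1.7-fold higher number from compound 3 to compound 4 (0.22 log units; within the scatter) is taken as no change beyond the scatter, with a wide range to reflect the missing comparison. Compound 4 is therefore estimated at 2500 nM in this assay, expected between 700 nM and 9000 nM.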

Compound 4, half-maximal inhibitory concentration: 2000 nM
Estimate against measurement, compound 4: 1.3-fold (0.10 log units) above; the measured number falls inside the stated range.
By their numbers in this assay, from the lowest: compounds 3 and 4 (each within the scatter of the next); then compounds 1 and 2 (each within the scatter of the next).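

In this assay, the step at the aromatic carbon next to the ring sulfur reads a 1.3-fold higher number from compound 3 to compound 4 (0.12 log units; within the scatter), so cyano and trifluoromethyl cannot be told apart at this position despite the difference in heavy atoms and hydrogen-bond acceptors. The lower numbers of this amide type therefore do not rest on trifluoromethyl alone, as the comparisons on the amide-type nitrogen also show: a 10-fold lower number from compound 2 to compound 4 (1.00 log units; beyond the scatter) and a 5.5-fold lower number from compound 1 to compound 4 (0.74 log units; beyond the scatter). No measurement shown here offers an explanation for these steps.

Still open, on these data alone, is whether a primary amine, a carboxylic acid or a longer alkyl chain at this ring carbon would stay within the scatter of compound 3 and compound 4. A plain hydrogen there would show whether any substituent at this position is needed.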